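The source may hold more compounds than are shown below. What is called first, only, known or untested is meant among the compounds shown, and "the series" means these compounds.

Compound 3 `CC(C)(C)C(=O)NC[C@@H]1CCCc2cc(S(=O)(=O)c3cccc(F)c3)ccc21` carries the highest number of the three measured in an assay on isolated protein for displacement of a labelled ligand from 5-hydroxytryptamine receptor 6 (Homo sapiens); a higher number here means a weaker inhibitor, a lower number a stronger inhibitor: compound 3 gives 3.98 nM, whereas compound 1 `CN(CC(N)=O)C[C@@H]1CCCc2cc(S(=O)(=O)c3cccc(F)c3)ccc21` gives 1.26 nM and compound 2 `COCCNC[C@@H]1CCCc2cc(S(=O)(=O)c3cccc(F)c3)ccc21` gives 0.251 nM. The gaps are read as a 3.2-fold higher number from compound 1 to compound 3 (0.50 log units; beyond the scatter) and a 16-fold higher number from compound 2 to compound 3 (1.20 log units; beyond the scatter); both lie beyond the scatter. Compound 4 `CS(=O)(=O)NC[C@@H]1CCCc2cc(S(=O)(=O)c3cccc(F)c3)ccc21` is next to be measured in this assay. Its change from compound 3 is methylsulfonyl in place of (tert-butyl)carbonyl on an amine nitrogen. Going by the values given here, no measured step exchanges one acyl substituent on that nitrogen for another, so the effect of the sulfonyl group itself is not seen directly. What the measured steps show is that the amide of compound 3 sits above the two amines, compound 1 by a 3.2-fold higher number from compound 1 to compound 3 (0.50 log units; beyond the scatter) and compound 2 by a 16-fold higher number from compound 2 to compound 3 (1.20 log units; beyond the scatter); compound 4 keeps that nitrogen non-basic and carries fewer heavy atoms on it. The expectation is therefore a number close to compound 3, with the step of a 1.3-fold higher number from compound 3 to compound 4 (0.10 log units; within the scatter) estimated to lie within or only slightly beyond the scatter and, if anything, toward a higher number. The estimate for compound 4 in this assay is 5 nM, expected to fall between 1.5 nM and 16 nM.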

Compound 4, inhibition constant: 0.2 nM
The estimate for compound 4 lay 25-fold (1.40 log units) above the measured number; measured number below the stated range.
By their numbers in this assay, from the lowest: compounds 4 and 2 (each within the scatter of the next); then compound 1; then compound 3.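

In this assay, the group on this amine nitrogen carries much of the outcome: methylsulfonyl in place of (tert-butyl)carbonyl gives a 20-fold lower number from compound 3 to compound 4 (1.30 log units; beyond the scatter), so the weak standing of the amide against the two amines does not extend to every group that replaces the amine substituents at this nitrogen. Methanesulfonamido reaches the level of the (2-methoxyethyl)amino side chain, with a 1.3-fold lower number from compound 2 to compound 4 (0.10 log units; within the scatter), which leaves those two without an order, and it also improves on the (carbamoylmethyl)(methyl)amino side chain, with a 6.3-fold lower number from compound 1 to compound 4 (0.80 log units; beyond the scatter). No measurement offered here gives a reason for these steps.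

Methylsulfonyl and (tert-butyl)carbonyl differ both in the linking group and in the size of what they carry, so the large step cannot yet be assigned to either difference; an acetyl group and a tert-butylsulfonyl group would pull the two apart. On these data alone, how far the sulfonamide tolerates growth also stays open, for instance with an ethylsulfonyl or phenylsulfonyl group on the same nitrogen.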